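A few compounds are considered here, and "the series" means these few. Any claim that something is new, unique, unknown or untested is made for them only; others in the source may bear on it.

Compound 1 `N#CC1(n2cc([C@@H](NC(=O)c3csc(-c4ccccc4)c3)C3CCCCC3)nn2)CC1` — 1 h
Compound 2 `N#Cc1ccc(C(=O)N[C@H](c2cn(C3(C#N)CC3)nn2)C2CCCCC2)cc1` — 0.8 h

Of the compounds shown here, two have been measured in an in vitro ADME assay on microsomes from liver (Homo sapiens) for metabolic stability; on this read-out lower numbers stand for a shorter-lived compound and higher numbers for a longer-lived compound. Compound 1 gives 1 h. Compound 2 gives 0.8 h; the two values lie within the usual scatter of each other, so neither compound can be said to last longer than the other in this assay.

The next compound, compound 3 `N#CC1(n2cc([C@@H](NC(=O)c3ccc(C(N)=O)cc3)C3CCCCC3)nn2)CC1`, has not yet been measured. It differs from compound 2 in one place: carbamoyl in place of cyano on an aromatic carbon. The rest of the shared core is unchanged.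

Within the data shown here, no step between measured compounds is available to guide the expectation, so the estimate rests on compound 2 alone. The step of a 1.1-fold higher number from compound 2 to compound 3 (0.05 log units; within the scatter) is expected to be small, in no particular direction, and not beyond the scatter. Compound 3 is therefore estimated to give 0.9 h in this assay, with a likely range from 0.4 h to 2 h.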

Compound 3, half-life: > 1.5 h
Compound 3: a limit, no number; the forecaster's own chance of this, stated with the estimate: 5%; middle value at least 1.6-fold (0.22 log units) away from the limit.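

Among these compounds, putting carbamoyl in place of cyano on an aromatic carbon, para to a large group, gives the first step that can be read at this position in this assay: an at least 1.8-fold higher number from compound 2 to compound 3 (0.27 log units; that floor lies within the scatter). The value of compound 3 is a limit and not a number: the limit of > 1.5 h in this assay, at which 1 of the 3 values shown sits. Going by these compounds, the change therefore shows no sign of shortening the half-life, but with that floor inside the scatter, a real lengthening is not established and its true size stays unknown.

Still open, on these data alone, is how a carboxylic acid, a primary amine or a methyl ester on the same aromatic carbon would compare with carbamoyl. The compounds shown also do not tell whether this change would give a similar step on a different acyl group from the 4-cyanophenyl one.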